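Swapping chloro for methyl on a chalcone sulfonamide

A few compounds are considered here, and "the series" means these few. Any claim that something is new, unique, unknown or untested is made for them only; others in the source may bear on it.

Measured compounds:
compound 1 `C/C(=N\n1c(N)cc(N)c(C#N)c1=O)c1ccc(NS(=O)(=O)c2ccc(C)cc2)cc1` — 37000 nM
compound 2 `Cc1ccc(S(=O)(=O)Nc2ccc(-c3cc(-c4ccc([N+](=O)[O-])cc4)n(-c4ccccc4)n3)cc2)cc1` — "not active" (no number reported)
compound 3 `Cc1ccc(S(=O)(=O)Nc2ccc(C(=O)/C=C/c3ccc(Cl)cc3)cc2)cc1` — 43300 nM

In a functional assay on HepG2 cells (Homo sapiens) for cytotoxicity, read by sulforhodamine B assay, with a stated time of 48 h (a lower number here means a stronger inhibitor, a higher number a weaker inhibitor), compound 3 gives 43300 nM, the higher of the two numbers recorded; compound 1 sits a short way off, within the usual scatter, so the two cannot be ordered. For compound 2 the result is reported only as "not active" (no number reported), without a number.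

Compound 4 `Cc1ccc(/C=C/C(=O)c2ccc(NS(=O)(=O)c3ccc(C)cc3)cc2)cc1` has not yet been measured. It differs from compound 3 by methyl in place of chloro on an aromatic carbon, with the change placed on an aromatic carbon, para to a large group. Among the measured compounds shown here, no measured pair here shows the effect of this change, so no step beyond the scatter is expected in either direction. Compound 4 is therefore estimated at 45000 nM, between 20000 nM and 100000 nM, a step of a 1.0-fold higher number from compound 3 to compound 4 (0.02 log units; within the scatter) that is expected to stay within the scatter.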

Compound 4, half-maximal inhibitory concentration: 49800 nM
For compound 4 the middle estimate is 1.1-fold (0.04 log units) below the measured one; measured number inside the range.
By their numbers in this assay, from the lowest: compounds 1, 3 and 4 (each within the scatter of the next).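

In this assay methyl in place of chloro on this aromatic carbon, para to a large group, gives a step that stays within the scatter (a 1.2-fold higher number from compound 3 to compound 4 (0.06 log units; within the scatter)). Among the compounds shown here, this is the first measured pair at this position, and it shows that these two groups cannot be told apart here. Nothing measured here offers an explanation for this result.

Still open, on these data alone, is whether a larger or different group at this position, such as an amine, a carboxylic acid or a methoxy group, would move the number beyond the scatter.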